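Series notes: removing the ring-nitrogen amino, cytotoxicity read-out

The compounds below may be only part of what the source reports. "The series", "measured", "known", "first", "only" and "open" are said of these compounds alone.

Compound 1 `O=C1NC(=S)S/C1=C\c1c[nH]c2ccccc12`: > 50000 nM
Compound 2 `NN1C(=O)/C(=C/c2c[nH]c3ccc(Br)cc23)SC1=S`: > 50000 nM

In a functional assay on MCF7 cells (Homo sapiens) for cytotoxicity, read by MTT assay, with a stated time of 72 h (a higher number here means a weaker inhibitor, a lower number a stronger inhibitor), compound 1 gives only the assay limit, > 50000 nM. In this assay compound 2 also gives only a limit, > 50000 nM. Compound 2 therefore stands at the limit of > 50000 nM in this assay, at which 2 of the 2 values shown sit, with no number to place it. Compound 3 `O=C1NC(=S)S/C1=C\c1c[nH]c2ccc(Br)cc12` differs from compound 2 by hydrogen in place of amino on an amide-type nitrogen in a ring. Going by the values given here, no measured step joins these two compounds. Because both measured values sit at the limit of > 50000 nM in this assay, at which 2 of the 2 values shown sit, no step beyond the scatter is expected. Compound 3 is expected to stay at the limit, estimated near 60000 nM (range 20000 nM to 200000 nM). The expected step is a step that the limit leaves unreadable from compound 2 to compound 3.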

Compound 3, half-maximal inhibitory concentration: 3650 nM
Compound 3: middle estimate off by 16-fold (1.22 log units), on the high side; the measured number lies below the stated range.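

With bromo on the aromatic carbon held constant, hydrogen in place of amino on the amide-type nitrogen in a ring gives an at least 13-fold lower number from compound 2 to compound 3 (1.13 log units; beyond the scatter) in this assay. With hydrogen on that nitrogen held constant, bromo in place of hydrogen gives an at least 13-fold lower number from compound 1 to compound 3 (1.13 log units; beyond the scatter). Only the compound carrying both hydrogen on the nitrogen and bromo leaves the limit, and its two neighbours stay there: the limit of > 50000 nM in this assay, at which 2 of the 3 values shown sit.

Going by these compounds, whether a methyl group or a longer chain on that nitrogen would keep a readable value remains open. So does whether chloro could stand in place of bromo.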